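Replacing tert-butoxycarbonyl with 4-hydroxyphenyl on compound 3

The compounds below may be only part of what the source reports. "The series", "measured", "known", "first", "only" and "open" are said of these compounds alone.

Compound 1 (`COc1ccc2c(=O)cc(C)[nH]c2c1`) gives > 52800 nM (a limit)
Compound 2 (`CCCCCCCc1c(C)nc2ccccc2c1O`) gives 5100 nM (a number)
Compound 3 (`Cc1[nH]c2ccccc2c(=O)c1/C=C/C(=O)OC(C)(C)C`) gives > 40000 nM (a limit)

In an ADME assay on J774 cells (Mus musculus) for cytotoxicity (on this read-out lower numbers stand for an effect already at smaller amounts and higher numbers for an effect only at larger amounts of compound), compound 3 reports > 40000 nM as a limit of the assay and not as a number. Compound 1 also stands at a limit, and compound 2 is the only one of the three with a measured number. Compound 3 therefore has no exact position on the scale.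

Compound 4 (`Cc1[nH]c2ccccc2c(=O)c1/C=C/c1ccc(O)cc1`) carries 4-hydroxyphenyl in place of tert-butoxycarbonyl on a double-bonded chain carbon bound to a double-bonded chain carbon. For the measured compounds named here, no two measured compounds differ in one place only, and the set gives no direct guide to this change.

Compound 2 (5100 nM) shows that a compound in this small set can give a number in the assay, and this is the only basis for expecting a move. In this assay a moderate step toward lower numbers is expected (an at least 2.0-fold lower number from compound 3 to compound 4 (0.30 log units; that floor lies within the scatter)) although another result reported only as a limit remains possible. Compound 4 is estimated at 20000 nM with an expected range from 7000 nM to 55000 nM in the coming measurement.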

Compound 4, half-maximal effective concentration in the J774 assay: > 36100 nM
Compound 4: only a limit was reported; the forecaster's own chance of this, stated with the estimate: 35%; middle value at least 1.8-fold (0.25 log units) away from the limit.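

In the J774 assay compound 3 gives > 40000 nM, which is a limit of the assay and not a number. In the J774 assay compound 4 gives > 36100 nM, which is also a limit of the assay and not a number. For the compounds shown here, no step between the two can be read. The compounds shown leave open where either one lies on this scale, and whether 4-hydroxyphenyl in place of tert-butoxycarbonyl changes the read-out at all. In a physicochemical assay for lipophilicity, at pH 7.4 (a higher number here means a more lipophilic compound, a lower number a more polar compound), compound 3 gives 2.34 and compound 4 gives 1.77, which is a number 0.57 log units lower from compound 3 to compound 4 (beyond the scatter).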